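Fluoro for methyl on the pendant phenyl ring

A few compounds are considered here, and "the series" means these few. Any claim that something is new, unique, unknown or untested is made for them only; others in the source may bear on it.

Four analogues share one core. For the measured compounds named here, compound 1 `COc1cc2c(Oc3ccc(NC(=O)c4nccc(-c5ccc(F)cc5)n4)cc3F)ccnc2cc1OCCCN1CCN(C)CC1` is the only one with a number: in a functional assay on A549 cells (Homo sapiens) for cytotoxicity, read by MTT assay, with a stated time of 72 h (on this read-out higher numbers stand for weaker inhibition and lower numbers for stronger inhibition), compound 1 gives 680 nM. Compound 2 `COc1cc2c(Oc3ccc(NC(=O)c4nccc(-c5ccccc5)n4)cc3F)ccnc2cc1OCCCN1CCCC1` carries an unsubstituted phenyl ring and a pyrrolidine tail, and in this assay compound 2 is recorded as "not determined" (no result reported), no result having been reported. Compound 3 `COc1cc2c(Oc3ccc(NC(=O)c4nccc(-c5ccc(C)cc5)n4)cc3F)ccnc2cc1OCCCN1CCCC1` carries a 4-methylphenyl ring and the same pyrrolidine tail; in this assay compound 3 is likewise recorded as "not determined" (no result reported), with no single number, so compound 3 stands nowhere on the numbers shown, and it shares this blank with one further entry, compound 2.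

Compound 4 `COc1cc2c(Oc3ccc(NC(=O)c4nccc(-c5ccc(F)cc5)n4)cc3F)ccnc2cc1OCCCN1CCCC1` has not been measured. It differs from compound 3 by fluoro in place of methyl on an aromatic carbon, in words: fluoro in place of methyl on an aromatic carbon, para to a large group, or, cut one bond further out, 4-methylphenyl to 4-fluorophenyl. Going by the values given here, no measured pair shows this change, so the size of the step cannot be read from the data; within this assay no step beyond the usual scatter is expected in either direction. Compound 4 shares its 4-fluorophenyl ring with compound 1, and because compound 1 gives 680 nM, compound 4 is expected to give about 650 nM, estimated between 200 nM and 2500 nM.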

Compound 4, half-maximal inhibitory concentration: 990 nM
Compound 4: the middle estimate sits 1.5-fold (0.18 log units) below what was measured; the measured number falls inside the stated range.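

For the compounds shown here, with the 4-fluorophenyl ring held fixed, the first comparison concerns the tail rather than the pendant ring: in this assay, pyrrolidin-1-yl in place of 4-methylpiperazin-1-yl on the saturated chain carbon gives a 1.5-fold higher number from compound 1 to compound 4 (0.16 log units; within the scatter). This exchange therefore makes no difference beyond the usual scatter for this pair, and compound 4 gives the pyrrolidine tail its first number, 990 nM, in this read-out. No measurement shown here offers an explanation for the result or separates the contributions of the two tails to cytotoxicity.

The fluoro for methyl change itself cannot be read, and neither can any other step involving compound 2 or compound 3, as neither has a number in this assay. Also open, from the compounds shown here alone, are the effects of chloro or methoxy on the same aromatic carbon of the pendant ring, and of a morpholin-4-yl tail or a longer chain at the other end of the molecule.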